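The compounds below may be only part of what the source reports. "The series", "measured", "known", "first", "only" and "open" are said of these compounds alone.

Working notes on the series. Going by the values given here, in a functional assay on WI-38 VA13 cells (Homo sapiens) for cytotoxicity (a lower number here means that less compound is needed, a higher number that more compound is needed for the effect), compound 2 `COc1ccccc1C(=O)c1oc2cc(-c3ccccc3)cc(O)c2c1C` gives 0.09 ug/mL, the lower of the two numbers measured so far; compound 1 `Cc1c(C(=O)c2ccc(F)c(F)c2)oc2cc(-c3ccccc3)cc(O)c12` gives 0.4 ug/mL in this assay. Among the compounds with values here, the one measured step, a 4.4-fold lower number from compound 1 to compound 2 (0.65 log units; beyond the scatter), exchanges the whole aryl group on the carbonyl carbon. Compound 3 `COc1ccc(OC)c(C(=O)c2oc3cc(-c4ccccc4)cc(O)c3c2C)c1` differs from compound 2 in a single spot: methoxy in place of hydrogen on an aromatic carbon. Within the data shown here, no measured step adds a methoxy to the ring on the carbonyl carbon, so the step from compound 1 to compound 2 bears on it only indirectly, showing that this ring tolerates a change of substituents with a modest shift. A second methoxy is therefore expected to move the number little, if at all, beyond the scatter. For compound 3 the estimated result is 0.1 ug/mL (range 0.04 ug/mL to 0.3 ug/mL), an expected step of a 1.1-fold higher number from compound 2 to compound 3 (0.05 log units; within the scatter).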

Compound 3, half-maximal effective concentration: 0.09 ug/mL
Beside the measured number, compound 3's estimate is 1.1-fold (0.05 log units) above it, and the stated range covers the measured number.
By their numbers in this assay, from the lowest: compounds 2 and 3 (each within the scatter of the next); then compound 1.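

In this assay the added methoxy gives no change at the digits printed from compound 2 to compound 3 (within the scatter), so this aromatic carbon, meta to a large group and para to a methoxy group, accepts methoxy in place of hydrogen with no shift beyond the scatter. Going by these compounds alone, this is the first direct reading at this position: the earlier step exchanged the whole aryl group on the carbonyl carbon, whereas here one substituent enters and the other methoxy stays in place. Nothing at hand explains why the number stays the same.

The compounds shown leave open whether this position would also accept an amine, a carboxylic acid or a longer chain in place of the methoxy. They also leave open whether a methoxy here would give the same number without the other methoxy on the ring.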